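A sulfonyl exchange on compound 2

A few compounds are considered here, and "the series" means these few. Any claim that something is new, unique, unknown or untested is made for them only; others in the source may bear on it.

Compound 1 `N#C/C(=C\c1ccccc1OS(=O)(=O)c1ccc(F)cc1)C(=O)Nc1nnc(Cc2ccccc2)s1`: 69%
Compound 2 `N#C/C(=C\c1ccccc1OS(=O)(=O)c1ccccc1[N+](=O)[O-])C(=O)Nc1nnc(Cc2ccc(F)cc2)s1`: 61%

In a functional assay on RS4-11 cells (Homo sapiens) for inhibition, read by CCK-8 assay, with a stated time of 48 h, tested at 20 uM (a higher number here means more inhibition of growth at the concentration tested, a lower number less inhibition of growth), compound 2 gives 61%, a value within the usual scatter of compound 1 at 69%. Compound 3 `N#C/C(=C\c1ccccc1OS(=O)(=O)c1ccc(F)cc1)C(=O)Nc1nnc(Cc2ccc(F)cc2)s1` has 4-fluorophenyl in place of 2-nitrophenyl on a sulfonyl sulfur. For the measured compounds named here, no measured pair shows this change alone. Compound 1 also carries 4-fluorophenyl there and gives 69%, so no step beyond the scatter is expected. The estimated change is small, a number 4 percentage points higher from compound 2 to compound 3 (within the scatter). For compound 3 the expected value is 65%, with an estimated range from 50% to 79%.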

Compound 3, percent growth inhibition at one concentration: 59%
The estimate for compound 3 lay 6 percentage points above the measured number; measured number inside the range.
By their numbers in this assay, from the lowest: compounds 3, 2 and 1 (each within the scatter of the next).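

In this assay the exchange of 2-nitrophenyl for 4-fluorophenyl on a sulfonyl sulfur now reads directly as a number 2 percentage points lower from compound 2 to compound 3 (within the scatter) and so separates the two groups by nothing beyond the scatter. Fluoro in place of hydrogen on an aromatic carbon reads as a number 10 percentage points lower from compound 1 to compound 3 (within the scatter) and likewise stays inside it. Nothing measured here gives a reason for either step.

Still open, going by these compounds, is whether a methyl group or a longer alkyl chain on the sulfonyl sulfur, or an amine or carboxylic acid on its aromatic ring, would give a number beyond the scatter.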